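The source may report more compounds than this note shows. Statements on the series, on what has been measured and on what is new or still open speak of the compounds shown alone.

Working notes on the series. Compound 1 `COc1cc(C)cc(-c2c(-c3ccnc(-c4ccc(C(C)=O)cc4)c3)cnn2CC#N)c1` is read in a functional assay on M14 cells (Homo sapiens) for cytotoxicity, read by sulforhodamine B assay, with a stated time of 48 h, tested at 100 nM (on this read-out lower numbers stand for a stronger effect and higher numbers for a weaker effect at the one concentration tested), and gives 79%. Compound 2 `COc1cc(C)cc(-c2nn(CC#N)cc2-c2ccc(-c3cccc(C(C)=O)c3)nc2)c1` gives 58% in this assay, and compound 3 `Cc1cc(O)cc(-c2nn(CC#N)cc2-c2ccnc(-c3ccc(Oc4ccccc4)cc3)c2)c1` gives 94%. Among these three numbers compound 1 stands second highest: the nearest is compound 3, higher by a margin beyond the scatter, and the furthest is compound 2, lower by a margin beyond the scatter. No two of the measured compounds differ in only one place, so no single-change step can be read from them.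

Compound 4 `COc1cc(C)cc(-c2c(-c3ccnc(-c4ccc(N(C)C)cc4)c3)cnn2CC#N)c1` is not yet measured. It differs from compound 1 as follows: dimethylamino in place of acetyl on an aromatic carbon. Cut one bond further out, the same change reads 4-acetylphenyl to 4-(dimethylamino)phenyl. The measured set holds nothing that shows what this exchange does in this assay, and all three numbers sit in the weak part of the range at the single concentration. The step is therefore expected to be small, a number 3 percentage points higher from compound 1 to compound 4 (within the scatter), not beyond the scatter in either direction. Compound 4 is expected to give about 82% in this assay, with a likely range from 62% to 100%.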

Compound 4, a percentage reported as activity, at one concentration (the size of the read-out at that concentration, not a potency): -16%
Compound 4: the middle estimate sits 98 percentage points above what was measured; measured number outside the range, below it.
By their numbers in this assay, from the lowest: compound 4; then compound 2; then compound 1; then compound 3.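

In this assay, the exchange of 4-acetylphenyl for 4-(dimethylamino)phenyl gives a large step, a number 95 percentage points lower from compound 1 to compound 4 (beyond the scatter), showing that the read-out at the one concentration tested is highly sensitive to the group at this place on the aromatic ring. Acetyl and dimethylamino have the same counts of heavy atoms, hydrogen-bond donors and hydrogen-bond acceptors, so those counts alone do not separate the two compounds. No available measurement explains the size of this step.

The compounds shown leave open whether the effect is specific to dimethylamino or would also appear with a primary amine, a morpholine or a methoxy group at this place. They also leave open whether the same exchange would produce a comparable step on the core of compound 2.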